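This account rests on a few compounds, and the source may have more. Where it says the series, first, only, none or still open, it means among the compounds named here.

Working notes on the series. Compound 2, `Fc1ccc(-c2cn3ccnc3c(-c3ccc4ncn(C5CCCCC5)c4c3)n2)cc1`, gives 12.8% in a functional assay on A549 cells (Homo sapiens) for inhibition, read by sulforhodamine B assay, with a stated time of 48 h, tested at 10 uM; a lower number here means less inhibition, a higher number more inhibition at the concentration tested (going by the name of the read-out). Within the data shown here, only one other compound has a number there: compound 1, `Brc1cn2ccnc2c(-c2ccc3ncn(C4CCCCC4)c3c2)n1`, which in this assay gives 9.36%; the two stand together, since a number 3.4 percentage points higher from compound 1 to compound 2 (within the scatter) falls within the scatter. Compound 3, `c1cn2cc(-c3ccsc3)nc(-c3ccc4ncn(C5CCCCC5)c4c3)c2n1`, is not yet measured; against compound 2 its difference is thiophen-3-yl in place of 4-fluorophenyl on an aromatic carbon. Among the measured compounds shown here, the single measured step, from bromo to 4-fluorophenyl at this position, bears on the change only in that it alters the same position, and it produced nothing beyond the scatter. For the measured compounds named here, no step with a thiophen-3-yl group is known. The expectation for compound 3 is therefore a step within the scatter, a number 0.8 percentage points lower from compound 2 to compound 3 (within the scatter), in no firm direction. Compound 3 is estimated at 12% in this assay, expected to fall between 3% and 26%.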

Compound 3, a percentage reported as inhibition, at one concentration (the size of the read-out at that concentration, not a potency): 3.97%
For compound 3 the middle estimate is 8 percentage points above the measured one, within the range that was stated.
By their numbers in this assay, from the lowest: compounds 3, 1 and 2 (each within the scatter of the next).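

In this assay the position next to the ring nitrogen now carries a third group, thiophen-3-yl, and the step from 4-fluorophenyl (a number 8.8 percentage points lower from compound 2 to compound 3 (within the scatter)) stays inside the scatter, as does the step from bromo (a number 5.4 percentage points lower from compound 1 to compound 3 (within the scatter)). Replacing the six-membered carbon ring with a five-membered aromatic ring holding sulfur thus separates these compounds no more clearly than the earlier change from bromo to 4-fluorophenyl did, so bromo and both aromatic rings cannot be ranked at this position. No measurement on hand offers an explanation for these numbers.

Still open, going by these compounds, is whether an amine or a carboxylic acid at this position would move the number beyond the scatter. Also open, on these data alone, is whether any change to the cyclohexyl group would do so.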